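Cyano in place of nitro in the shared core series

The compounds below may be only part of what the source reports. "The series", "measured", "known", "first", "only" and "open" are said of these compounds alone.

Three compounds of this series have been run in a toxicity assay on NIH3T3 cells (Mus musculus) for cytotoxicity, read by resazurin assay (a higher number here means that more compound is needed for the effect, a lower number that less compound is needed), and none gave a number. Compound 1 `COC(=O)c1ccc(NCc2cncn2Cc2ccc([N+](=O)[O-])cc2)cc1-c1ccccc1` reached only a limit of the assay, > 10000 nM. Compound 2 `c1ccc(-c2ccc(Cn3cncc3CNc3ccc(N4CCCC4)c(-c4ccccc4)c3)cc2)cc1` likewise sits at a limit, > 1000 nM. Compound 3 `Cc1ccccc1-c1cc(NCc2cncn2Cc2ccc(-c3ccccc3)cc2)ccc1-c1nc2ccccc2s1` also stops at a limit, > 1000 nM. Going by the values given here, compound 1 therefore stands at the limit of > 10000 nM in this assay, at which 1 of the 3 values shown sits, while the other two stand at the limit of > 1000 nM in this assay, at which 2 of the 3 values shown sit; no ordering among the three can be read from this, and no step between measured compounds is available.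

Compound 4 `COC(=O)c1ccc(NCc2cncn2Cc2ccc(C#N)cc2)cc1-c1ccccc1` is the next one to be measured in this assay. Against compound 1 the change is cyano in place of nitro on an aromatic carbon. Among the compounds with values here, with no measured step to lean on and all three values at limits, the expectation for compound 4 is that this change moves the readout by nothing beyond the scatter, in either direction, so that a limit is again the most likely outcome.

Compound 4 is accordingly expected to come out near 15000 nM, within a range of 5000 nM to 50000 nM. The expected step that the limit leaves unreadable from compound 1 to compound 4 is estimated as essentially flat.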

Compound 4, half-maximal effective concentration: > 10000 nM
Compound 4 ended at the assay's limit (the forecaster's own chance of this, stated with the estimate: 85%); the middle value lies beyond the limit too.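

In this assay, going by these compounds alone, compound 1 and compound 4 both stop at a limit of the assay, so no step for cyano in place of nitro can be read from this pair. Both stand at the same limit: the limit of > 10000 nM in this assay, at which 2 of the 4 values shown sit.

The compounds shown leave open whether this change has any effect on the readout, and of what size.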